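Swapping the Dimethoxyphenyl Group: From Compound 2 to Compound 4

The compounds below may be only part of what the source reports. "The series", "measured", "known", "first", "only" and "open" are said of these compounds alone.

Three compounds have been measured in a functional assay on the whole organism (artery, strain albino) with Rattus norvegicus as the target, with a stated time of 720 min, at a dose of 10 mg/kg by the oral route; on this read-out higher numbers stand for more inhibition at the one dose given (going by the name of the read-out) and lower numbers for less inhibition:
Compound 1 `COc1ccc(C2N=C(SCc3ccccc3Cl)NC(C)=C2C(=O)Nc2ccc(F)cc2)cc1OC` gives 23.2%.
Compound 2 `COc1ccc(C2N=C(SCc3ccc(Cl)cc3)NC(C)=C2C(=O)Nc2ccc(F)cc2)cc1OC` gives 22.2%.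
Compound 3 `COc1ccc(C2N=C(SCc3ccc(F)cc3)NC(C)=C2C(=O)Nc2ccc(F)cc2)cc1OC` gives 17%.

Compound 2 stands second highest of the three, with compound 1 nearest (a number 1 percentage points lower from compound 1 to compound 2 (within the scatter)) and compound 3 furthest (a number 5.2 percentage points lower from compound 2 to compound 3 (within the scatter)); all three values lie within the scatter of one another. Compound 4 `CC1=C(C(=O)Nc2ccc(F)cc2)C(c2ccc([N+](=O)[O-])cc2)N=C(SCc2ccc(Cl)cc2)N1` differs from compound 2 by 4-nitrophenyl in place of 3,4-dimethoxyphenyl on a saturated ring carbon. Among the measured compounds shown here, every measured step, including a number 6.2 percentage points lower from compound 1 to compound 3 (within the scatter), concerns the group on the saturated chain carbon bound to a sulfur, and none touches the saturated ring carbon, so no measured step bears on this change. For compound 4 the expected step is a number 0.2 percentage points lower from compound 2 to compound 4 (within the scatter), nothing beyond the scatter. Compound 4 is therefore estimated at 22%, within 8% to 36%.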

Compound 4, a percentage reported as inhibition, in the whole organism at one dose (the size of the read-out at that dose, not a potency): 22.2%
For compound 4 the middle estimate is 0.2 percentage points below the measured one, within the range that was stated.
By their numbers in this assay, from the lowest: compounds 3, 2, 4 and 1 (each within the scatter of the next).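

Among the compounds shown here, this is the first measured change on the saturated ring carbon: in this assay, 4-nitrophenyl in place of 3,4-dimethoxyphenyl shows no change at the digits printed from compound 2 to compound 4 (within the scatter). With the (4-chlorobenzyl)sulfanyl group held fixed, the read-out at this one dose therefore does not separate these two aryl groups. Nothing available here explains why they read alike.

Going by these compounds, whether this holds alongside the 2-chlorophenyl of compound 1 or the 4-fluorophenyl of compound 3 stays open. So does what a 4-aminophenyl group or a cyclohexyl ring would give on this carbon.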